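Moving the hydroxyl on the aryl group of compound 3

The source may hold more compounds than are shown below. What is called first, only, known or untested is meant among the compounds shown, and "the series" means these compounds.

Compound 1, `Cn1cnc2c(N3CCCCC3)nc(-c3ccccc3O)nc21`: 20% in an assay on cells for displacement of a labelled ligand from adenosine receptor A3 (Homo sapiens), read by scintillation counting and radioligand binding, with a stated time of 180 min, tested at 10 uM; a lower number here means less inhibition, a higher number more inhibition at the concentration tested (going by the name of the read-out)
Compound 2, `CN1CCN(c2nc(-c3cccc(Cl)c3)nc3c2ncn3C)CC1`: 38.3% in this assay
Compound 3, `CN1CCN(c2nc(-c3ccccc3O)nc3c2ncn3C)CC1`: 15.3% in this assay

Compound 3 gives the lowest of the three numbers; compound 1 lies nearest, a number 4.7 percentage points lower from compound 1 to compound 3 (within the scatter), and compound 2 lies furthest, a number 23 percentage points lower from compound 2 to compound 3 (beyond the scatter). Compound 4, `CN1CCN(c2nc(-c3cccc(O)c3)nc3c2ncn3C)CC1`, differs from compound 3 in one place: 3-hydroxyphenyl in place of 2-hydroxyphenyl on an aromatic carbon. Of the measured steps, a number 23 percentage points lower from compound 2 to compound 3 (beyond the scatter) is the one that bears on this change, as that step also exchanged the aryl group on the same carbon and was modest in size; a number 4.7 percentage points lower from compound 1 to compound 3 (within the scatter) concerns another part of the molecule. Among the compounds with values here, no measured compound carries 3-hydroxyphenyl, so the direction remains open. Compound 4 is expected to give 24% in this assay, between 5% and 50%, a step of a number 8.7 percentage points higher from compound 3 to compound 4 (within the scatter) that is expected to stay within the scatter.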

Compound 4, a percentage reported as inhibition, at one concentration (the size of the read-out at that concentration, not a potency): 63.8%
For compound 4 the middle estimate is 39.8 percentage points below the measured one; measured number above the stated range.
By their numbers in this assay, from the lowest: compounds 3 and 1 (each within the scatter of the next); then compound 2; then compound 4.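

In this assay moving the hydroxyl alone, with the atoms unchanged, gives a number 48.5 percentage points higher from compound 3 to compound 4 (beyond the scatter) and so shows that on this aromatic carbon the placement of the hydroxyl on the phenyl group matters, not merely its presence. Hydroxy in place of chloro gives a number 25.5 percentage points higher from compound 2 to compound 4 (beyond the scatter) and thus reverses the order seen with 2-hydroxyphenyl, which stood lower than 3-chlorophenyl. No evidence at hand accounts for either step. Open, as far as these compounds go, is how 4-hydroxyphenyl, 3-methoxyphenyl or 3-aminophenyl would compare, and whether 3-hydroxyphenyl keeps this number with piperidin-1-yl in place of 4-methylpiperazin-1-yl.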